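The source may report more compounds than this note shows. Statements on the series, on what has been measured and on what is new or still open speak of the compounds shown alone.

Measured in an assay for inhibition of histone acetyltransferase KAT2B (Homo sapiens), read by TR-FRET, with a stated time of 10 min, tested at 50 uM; a lower number here means less inhibition, a higher number more inhibition at the concentration tested (going by the name of the read-out):
compound 1 `CCCCCCOc1ccc(/C=C2\SC(=S)N(CCCC(=O)O)C2=O)cc1` gives 8%
compound 2 `O=C(O)CCCCCN1C(=O)/C(=C2/C(=O)Nc3ccccc32)SC1=S` gives 9%

Both measured compounds sit at the low end of the inhibition scale in this assay. The value of compound 2 and the value of compound 1 lie within the usual scatter of each other, so neither compound can be set apart from the other on these two numbers; compound 2 is one of two weak readings, nothing more. Among the measured compounds shown here, no step between compound 1 and compound 2 is given beyond what the two values themselves show.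

Compound 3 `O=C(O)CCCCCN1C(=O)/C(=C2/C(=O)N(Cc3ccccc3)c3ccccc32)SC1=S` is the next compound of the series and has not yet been measured in this assay. Compared with compound 2 the difference is benzyl in place of hydrogen on an amide-type nitrogen in a ring.

For the measured compounds named here, with only two weak numbers available and no measured step to lean on, the expectation for compound 3 in this assay is a step that stays within the scatter, if anything a small one upward. The step from compound 2 to compound 3 is estimated at a number 3 percentage points higher from compound 2 to compound 3 (within the scatter). Compound 3 is expected to give about 12%, with a likely range from 0% to 30%.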

Compound 3, a percentage reported as inhibition, at one concentration (the size of the read-out at that concentration, not a potency): 13%
The estimate for compound 3 lay 1 percentage points below the measured number, within the range that was stated.
By their numbers in this assay, from the lowest: compounds 1, 2 and 3 (each within the scatter of the next).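

In this assay, among the compounds shown here, benzyl in place of hydrogen on an amide-type nitrogen in a ring gives a number 4 percentage points higher from compound 2 to compound 3 (within the scatter) and so provides the first single-place comparison. The position therefore accepts a benzyl, with its six-membered aromatic ring of carbon only, while the reading stays within the scatter of that of compound 2; the amide hydrogen is not needed to retain this weak reading, and the benzyl brings no gain that can be told apart from it. No measured information bears on why the change has so little visible effect.

On these data alone, it remains open whether a methyl or a 2-aminoethyl group on the same nitrogen would move the reading beyond the scatter, or whether this position matters at all on its own. Also open, as far as these compounds go, is whether the same change would leave a clearer mark in a compound with a much higher reading, as one step among weak readings at a single concentration says little about the position's wider scope.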